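The source may report more compounds than this note shows. Statements on the series, on what has been measured and on what is new or still open speak of the compounds shown alone.

The measured compounds in brief:

Compound 1, `Fc1ccc2nc(NCCCCN3CCN(c4cccc(Cl)c4Cl)CC3)nc(NCc3ccco3)c2c1`, in a functional assay on HCT-116 cells (Homo sapiens) for cytotoxicity, read by MTT assay, with a stated time of 2 days (a lower number here means a stronger inhibitor, a higher number a weaker inhibitor), gives 520 nM.
Compound 2, `Clc1cccc(N2CCN(CCCCNc3nc(NCc4ccco4)c4ccccc4n3)CC2)c1Cl`, in this assay gives 3200 nM.
Compound 3, `CCN(CC)CCNc1nc(NCc2ccco2)c2cc(F)ccc2n1`, in this assay gives "not determined" (no result reported), that is, no result was reported for it.

Compound 1 and compound 2 share one core and differ in a single place, where compound 2 carries hydrogen in place of fluoro on an aromatic carbon. This change is not a quiet one: a 6.2-fold higher number from compound 1 to compound 2 (0.79 log units; beyond the scatter). Compound 3 carries a different side chain on the core of compound 1, and the difference between the two cores is not broken down here. Compound 3 itself has no number in this assay, so it cannot serve as an anchor.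

Compound 4, `CCN(CC)CCNc1nc(NCc2ccco2)c2ccccc2n1`, stands to compound 3 as compound 2 stands to compound 1: it carries hydrogen in place of fluoro on an aromatic carbon. The two descriptions of the place match word for word, so this is the same change made on a second pair. The same change was measured once among these compounds, between compound 1 and compound 2, and it weakened the compound there. Without a value for compound 3, the expectation for compound 4 can rest only on that one step and on the level of compound 2, which already sits well above compound 1.

Compound 4 is therefore expected to give about 8000 nM in this assay, with the estimated range reaching from 1500 nM to 40000 nM, because a 6.2-fold higher number from compound 1 to compound 2 (0.79 log units; beyond the scatter).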

Compound 4, half-maximal inhibitory concentration: 25900 nM
Compound 4: middle estimate off by 3.2-fold (0.51 log units), on the low side; the range from low to high includes it.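

In this assay, for the compounds shown here, compound 4 gives 25900 nM, but compound 3 has no reported result, so no step from compound 3 to compound 4 can be read. Nothing shown here accounts for this value. The compounds shown leave open whether hydrogen in place of fluoro, which gave a 6.2-fold higher number from compound 1 to compound 2 (0.79 log units; beyond the scatter), has an effect of similar size in the pair of compound 3 and compound 4.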